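From propoxy to (methylsulfonyl)oxy on a shared core

The compounds below may be only part of what the source reports. "The series", "measured", "known", "first", "only" and "open" are said of these compounds alone.

compound 1 `CCCOc1cc(-c2ccccc2)nc2ccccc12` gives 6.9 ug/mL
compound 2 `COc1ccc2nc(-c3ccccc3)cc(O)c2c1` gives 0.33 ug/mL
compound 3 `COCOc1ccc(-c2cc(=O)c3ccccc3n2C)cc1` gives > 10 ug/mL (a limit)

All three compounds were tested in a functional assay on P388 cells (Mus musculus) for cytotoxicity; on this read-out higher numbers stand for an effect only at larger amounts of compound and lower numbers for an effect already at smaller amounts. Among the two true numbers, compound 1 stands highest at 6.9 ug/mL. Compound 2 reads 0.33 ug/mL, and the gap between these two values lies well beyond the usual scatter. For compound 3 the entry > 10 ug/mL is a limit and not a number.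

The next compound to be tested is compound 4 `CS(=O)(=O)Oc1cc(-c2ccccc2)nc2ccccc12`, which keeps the core of compound 1. It carries methylsulfonyl in place of propyl on an oxygen on an aromatic ring. Among the measured compounds shown here, no pair of measured compounds differs in one place only, so this exchange has no direct precedent in the data. The expectation therefore stays anchored to compound 1 at 6.9 ug/mL, and no shift beyond the scatter is expected in this assay. The estimated change is a 1.4-fold lower number from compound 1 to compound 4 (0.14 log units; within the scatter), a slight move towards a lower number that is expected to remain within the scatter. For compound 4 the expected value is 5 ug/mL, with an estimated range of 1.5 ug/mL to 12 ug/mL.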

Compound 4, half-maximal effective concentration: > 10 ug/mL
Compound 4 was reported as a limit (the forecaster's own chance of this, stated with the estimate: 25%); middle value at least 2.0-fold (0.30 log units) away from the limit.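

In this assay compound 4 gives > 10 ug/mL, which is a limit of the assay and not a number. Among the compounds shown here, the change from propoxy to (methylsulfonyl)oxy provides the first comparison here between compounds that differ in one place, and it reads as an at least 1.4-fold higher number from compound 1 to compound 4 (0.16 log units; that floor lies within the scatter); the exchange therefore shows no move towards a lower number, although the floor alone does not establish a shift beyond the scatter. How far the true value of compound 4 lies past that floor cannot be read, and this ceiling also applies elsewhere in the set: the limit of > 10 ug/mL in this assay, at which 2 of the 4 values shown sit.

The compounds shown leave open how the shared core would respond in this assay to an aminoethyl group or a longer alkyl chain on the same oxygen, and whether either would give a true number. They also leave open whether a carboxylic acid carried on a short chain at that place would give a lower number than compound 1 does at 6.9 ug/mL.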